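Shorter amide chain on the shared core: compound 2 to compound 4

The source may report more compounds than this note shows. Statements on the series, on what has been measured and on what is new or still open speak of the compounds shown alone.

Measured so far in an assay on isolated protein for inhibition of Myeloperoxidase (Homo sapiens), read by ELISA, with a stated time of 5 min; a higher number here means a weaker inhibitor, a lower number a stronger inhibitor:
compound 1 `NCCCc1c[nH]c2c(F)cccc12`: 26 nM
compound 2 `NC(=O)CCCCc1c[nH]c2ccc(F)cc12`: 43 nM
compound 3 `NCCCCc1c[nH]c2ccc(C(=O)O)cc12`: "not active" (no number reported)

For the measured compounds named here, only two compounds give a number in this assay. Compound 2 and compound 1 lie within the usual scatter of each other, so nothing separates them. Going by the values given here, compound 3 returned no number; it is reported as not active, and no step to it can be drawn.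

Compound 4 `NC(=O)CCc1c[nH]c2ccc(F)cc12` is the next entry. It differs from compound 2 in one place: carbamoyl in place of 2-carbamoylethyl on a saturated chain carbon, two bonds along the chain from an aromatic carbon. The side chain that carries the amide is thus shortened while the rest of the molecule is unchanged. Among the compounds with values here, no measured pair in this set shows the effect of such a shortening, so the size of the step is open. The numbers at hand show that compound 1 and compound 2, with side chains of different length and different end groups, sit close together in this assay, which argues against a large change.

The step from compound 2 to compound 4 is therefore expected to be modest, a 1.9-fold higher number from compound 2 to compound 4 (0.27 log units; within the scatter), with a loss more likely than a gain. For compound 4 the estimate in this assay is 80 nM, with a range from 25 nM to 300 nM.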

Compound 4, half-maximal inhibitory concentration: 34 nM
For compound 4 the middle estimate is 2.4-fold (0.37 log units) above the measured one; the range from low to high includes it.
By their numbers in this assay, from the lowest: compounds 1, 4 and 2 (each within the scatter of the next).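

Carbamoyl in place of 2-carbamoylethyl on a saturated chain carbon, two bonds along the chain from an aromatic carbon, gives the first single-change step in the series: in this assay it reads as a 1.3-fold lower number from compound 2 to compound 4 (0.10 log units; within the scatter) and stays within the scatter. Compound 2 and compound 4 therefore cannot be separated in this assay, so this pair gives no sign that the amide chain length on the shared core matters over this one change. Nothing measured here offers an explanation for this result.

Open, as far as these compounds go, is whether a chain longer than that of compound 2, or one shorter than that of compound 4, would also stay within the scatter. Also open, from the compounds shown here alone, is what replacing the terminal amide with an amine or a carboxylic acid would do on the same chain and the same core, which is the single-change comparison needed to judge the end group on its own.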